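One benzyl swap on a potent antagonist

A few compounds are considered here, and "the series" means these few. Any claim that something is new, unique, unknown or untested is made for them only; others in the source may bear on it.

Measured so far:
Compound 1, `O=C(O)c1nn(Cc2cc(Br)ccc2OCc2ccccc2)cc1Br`, in a functional assay on CHO-K1 cells for antagonist activity at prostaglandin E2 receptor EP1 subtype (Homo sapiens), read by FLIPR; on this read-out lower numbers stand for stronger inhibition and higher numbers for weaker inhibition: only a limit, < 2000 nM.
Compound 2, `O=C(O)c1nn(Cc2cc(Br)ccc2OCc2ccccc2)cc1CO`, in this assay: only a limit, < 2000 nM.
Compound 3, `Cc1cc(C(=O)O)nn1Cc1cc(Br)ccc1OCc1ccc(Cl)cc1Cl`, in this assay: 0.49 nM.

Going by the values given here, compound 3 is the only member of this set with a real number; the other two values are limits of the assay, as stated under (the limit of < 2000 nM in this assay, at which 2 of the 3 values shown sit). The step from compound 1 to compound 2 is a step that the two limits leave unreadable from compound 1 to compound 2, so it gives no readable size.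

Compound 4, `Cc1cc(C(=O)O)nn1Cc1cc(Br)ccc1OCc1ccc(F)cc1`, differs from compound 3 in one place: 4-fluorophenyl in place of 2,4-dichlorophenyl on a saturated chain carbon bound to an oxygen on an aromatic ring. In other words, the 2,4-dichlorobenzyl group becomes a 4-fluorobenzyl group on the saturated chain carbon bound to an oxygen on an aromatic ring.

Among the compounds with values here, no measured step touches this kind of change, and the only readable step in the set cannot be sized. The expectation for compound 4 therefore rests on the number for compound 3 alone, with a wide spread allowed: the step from compound 3 to compound 4 is estimated at a 10-fold higher number from compound 3 to compound 4 (1.01 log units; beyond the scatter). Compound 4 is estimated to give 5 nM in this assay, within a range from 0.5 nM to 60 nM.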

Compound 4, inhibition constant: 11.8 nM
Compound 4: middle estimate off by 2.4-fold (0.37 log units), on the low side; the range from low to high includes it.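

In this assay, changing the 2,4-dichlorobenzyl group to a 4-fluorobenzyl group gives a 24-fold higher number from compound 3 to compound 4 (1.38 log units; beyond the scatter), a large step. This shows that the read-out is sensitive to what the phenyl ring carries at this place, on a saturated chain carbon bound to an oxygen on an aromatic ring, even though compound 4 still gives a measured 11.8 nM. Going by these compounds alone, the earlier compounds could not show this: the only earlier step changes a different place, and it cannot be read.

This single step removes the chlorine atoms and adds fluorine together, leaving open which part of the change accounts for its size. Also open is where a phenyl ring carrying trifluoromethyl would fall, and nothing given here explains the size of this step.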